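A few compounds are considered here, and "the series" means these few. Any claim that something is new, unique, unknown or untested is made for them only; others in the source may bear on it.

Compound 1 (`O=C(CCCCc1ccccc1)CC(=O)N[C@H]1CCOC1=O`), compound 2 (`O=C(CCCCCc1ccccc1)CC(=O)N[C@H]1CCOC1=O`) and compound 3 (`O=C(CCCCCCc1ccccc1)CC(=O)N[C@H]1CCOC1=O`) share one core and differ in the chain that ends in the aromatic ring. In a functional assay on NCI-H630 cells (Homo sapiens) for cytotoxicity, read by sulforhodamine B assay, with a stated time of 5 days (on this read-out lower numbers stand for stronger inhibition and higher numbers for weaker inhibition), compound 1 gives > 100000 nM, which is a limit of the assay and not a number. In this assay, for the measured compounds named here, compound 2 gives 44000 nM, the only true number available so far. Compound 3 differs from it by one change: benzyl in place of phenyl on a saturated chain carbon, five bonds along the chain from a carbonyl carbon. In words, this is benzyl in place of phenyl on a saturated chain carbon, five bonds along the chain from a carbonyl carbon. Going by the values given here, only one measured step bears on this, the same replacement made four bonds along the chain from a carbonyl carbon, which gave an at least 2.2-fold lower number from compound 1 to compound 2 (0.35 log units; beyond the scatter). That step has a limit at one end, so it fixes a direction and a minimum size only. In this assay a further modest step towards a lower number, and so stronger inhibition, is therefore expected. The estimated change is a 2.2-fold lower number from compound 2 to compound 3 (0.34 log units; beyond the scatter). Compound 3 is expected at 20000 nM, with an estimated range of 7000 nM to 60000 nM.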

Compound 3, half-maximal inhibitory concentration: 65000 nM
Estimate against measurement, compound 3: 3.3-fold (0.51 log units) below, and the stated range ends below it.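

In this assay, the replacement of phenyl by benzyl, now on a saturated chain carbon five bonds along the chain from a carbonyl carbon, gives a 1.5-fold higher number from compound 2 to compound 3 (0.17 log units; within the scatter), so these two chain lengths cannot be told apart on this read-out. The step seen four bonds along the chain is therefore not shown to continue at this position, and the series gives no trend beyond that single step. Across both additions, phenethyl in place of phenyl four bonds along the chain from a carbonyl carbon gives an at least 1.5-fold lower number from compound 1 to compound 3 (0.18 log units; that floor lies within the scatter), and this comparison fixes only a floor because the value of compound 1 is a limit of the assay and not a number: the limit of > 100000 nM in this assay, at which 1 of the 3 values shown sits.

As far as these compounds go, it remains open whether a longer chain than that of compound 3 would give a number beyond the scatter from compound 2, and how far compound 1 truly lies from the other two. Also open, from the compounds shown here alone, is how the shared core would behave with an amine or a carboxylic acid in place of the phenyl at the chain end.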